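A few compounds are considered here, and "the series" means these few. Any claim that something is new, unique, unknown or untested is made for them only; others in the source may bear on it.

Measured so far in an assay on LX2 cells for inhibition of COL1A1 promoter (Homo sapiens), read by a luciferase reporter, with a stated time of 24 h, tested at 50 uM; a higher number here means a stronger effect of the compound at the concentration tested, a lower number a weaker effect:
compound 1 `CC[N+]1(CCCCCCCOc2ccc(-n3cc(C(=O)Nc4cc(F)cc(F)c4)c(=O)c4ccc(N(C)C)nc43)cc2C)CCCCC1` gives 53.4%
compound 2 `CC[N+]1(CCCCCCCOc2ccc(-n3cc(C(=O)Nc4cc(F)cc(F)c4)c(=O)c4ccc(N(C)C)nc43)cc2Cl)CCCCC1` gives 50.4%
compound 3 `CC[N+]1(CCCCCCCOc2ccc(-n3cc(C(=O)Nc4cc(F)cc(F)c4)c(=O)c4ccc(N(C)C)nc43)cc2C)CCCC1` gives 82.5%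

Compound 3 stands highest of the three in this assay; its step from compound 1 is a number 29.1 percentage points higher from compound 1 to compound 3 (beyond the scatter), and the two cores differ by a group of 7 heavy atoms (6 carbon, 1 nitrogen; one five-membered non-aromatic ring with 1 hetero atom) in place of a group of 8 heavy atoms (7 carbon, 1 nitrogen; one six-membered non-aromatic ring with 1 hetero atom), on a saturated chain carbon, seven bonds along the chain from an oxygen on an aromatic ring. Compound 1 and compound 2 differ by chloro in place of methyl on an aromatic carbon, and that change gave a number 3 percentage points lower from compound 1 to compound 2 (within the scatter).

Compound 4 `CC[N+]1(CCCCCCCOc2ccc(-n3cc(C(=O)Nc4cc(F)cc(F)c4)c(=O)c4ccc(N(C)C)nc43)cc2Cl)CCCC1` has not been measured in this assay. It differs from compound 3 by chloro in place of methyl on an aromatic carbon. The place of this change is described in the same words as for the pair compound 1 to compound 2, so it is the same change, now made on the core of compound 3 rather than that of compound 1. Within the data shown here, only one earlier instance exists, so the expectation rests on a single pair.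

Compound 4 is expected to give about 79%, within a range from 62% to 92%. The expected step is a number 3.5 percentage points lower from compound 3 to compound 4 (within the scatter), which rests on the measured step of a number 3 percentage points lower from compound 1 to compound 2 (within the scatter) being within the scatter.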

Compound 4, a percentage reported as inhibition, at one concentration (the size of the read-out at that concentration, not a potency): 23.5%
Beside the measured number, compound 4's estimate is 55.5 percentage points above it; measured number below the stated range.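

In this assay, chloro in place of methyl on an aromatic carbon gives a number 59 percentage points lower from compound 3 to compound 4 (beyond the scatter), so the change does not carry over unaltered from the core of compound 1 to the core of compound 3: the same change on two cores in this assay, a number 3 percentage points lower (within the scatter) from compound 1 to compound 2 and a number 59 percentage points lower (beyond the scatter) from compound 3 to compound 4, 56 percentage points apart, beyond the scatter of two such steps

The exchange of the six-membered ring group for the five-membered one gives a number 26.9 percentage points lower from compound 2 to compound 4 (beyond the scatter), opposite in direction to its step on the methyl-bearing pair: the same change on two cores in this assay, a number 29.1 percentage points higher (beyond the scatter) from compound 1 to compound 3 and a number 26.9 percentage points lower (beyond the scatter) from compound 2 to compound 4, 56 percentage points apart, beyond the scatter of two such steps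

The two changes therefore do not act independently across these four compounds, but this single square, read at one concentration, gives no cause for that and no rule for other cores.

Open, going by these compounds, is whether fluoro or methoxy on the same aromatic carbon would depend on the ring group in the same way. Also open, on these data alone, is whether the dependence would persist with an open-chain diethylamino end group or with a shorter chain.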